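Substituent swap at the cytotoxicity limit

The compounds below may be only part of what the source reports. "The series", "measured", "known", "first", "only" and "open" are said of these compounds alone.

In an ADME assay on MDBK cells (Bos taurus) for cytotoxicity (a higher number here means that more compound is tolerated, a lower number that less compound is tolerated), compound 2 `CCC(CC)Cn1ccc2nc(-c3ccccc3)nc-2c1` gives > 100000 nM as a limit of the assay. Compound 1 `N#Cc1ccc(Cn2ccc3nc(-c4ccccc4)nc-3c2)cc1` gives > 100000 nM as a limit too. Within the data shown here, the one measured step that the two limits leave unreadable from compound 1 to compound 2 has no readable size, so it sets no direction. Compound 1 with 4-cyanophenyl and compound 2 with pentan-3-yl share only the limit of > 100000 nM in this assay, at which 2 of the 2 values shown sit, as evidence. Compound 3 `c1ccc(-c2nc3ccn(Cc4cccnc4)cc-3n2)cc1` brings pyridin-3-yl in place of pentan-3-yl on a saturated chain carbon bound to an aromatic nitrogen with pyridin-3-yl in place of pentan-3-yl on a saturated chain carbon bound to an aromatic nitrogen. No step beyond the scatter is expected in this assay here. The expected step is a number no higher from compound 2 to compound 3 (the limit leaves the size open) in this estimate. Compound 3 is expected at 100000 nM with an estimated range from 40000 nM to 200000 nM for now.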

Compound 3, half-maximal cytotoxic concentration: > 100000 nM
Compound 3: no number, only a limit; the forecaster's own chance of this, stated with the estimate: 75%; the middle value lies on the limit itself.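

Compound 3 also stands at a limit in this assay, and the steps among compound 1, compound 2 and compound 3 cannot be read. Going by these compounds, whether 4-cyanophenyl, pentan-3-yl and pyridin-3-yl differ at all in tolerated concentration remains open.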